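A few compounds are considered here, and "the series" means these few. Any claim that something is new, unique, unknown or untested is made for them only; others in the source may bear on it.

Measured so far in an ADME assay on PC-3 cells (Homo sapiens) for cytotoxicity, read by WST assay, tested at 100 uM; on this read-out higher numbers stand for more inhibition at the one concentration tested (going by the name of the read-out) and lower numbers for less inhibition:
compound 1 `O=C(Nc1ccc(Cl)cc1)C1CCCN(C(=O)c2cccc(-c3ccco3)c2)C1`, 0%
compound 2 `C=CCOc1cccc(NC(=O)C2CCCN(C(=O)c3cc(C(F)(F)F)cc(C(F)(F)F)c3)C2)c1`, 0%
compound 3 `O=C(Nc1ccc(Cl)nc1)C1CCCN(C(=O)c2cc(C(F)(F)F)cc(C(F)(F)F)c2)C1`, 25%

Compound 2 is level with compound 1 at the digits printed, within the scatter. For the measured compounds named here, compound 3 sits above both, the only step beyond the scatter in the set, a number 25 percentage points higher from compound 2 to compound 3 (beyond the scatter), a modest rise.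

Compound 4 `O=C(c1ccccc1)c1cccc(NC(=O)C2CCCN(C(=O)c3cc(C(F)(F)F)cc(C(F)(F)F)c3)C2)c1` is not yet measured. It differs from compound 2 in one place: benzoyl in place of allyloxy on an aromatic carbon. Going by the values given here, no measured step touches this position; the one recorded step exchanges the whole aryl group on the amide-type nitrogen, and its size is the only guide to what a change on that ring can do. With compound 2 at the floor of the read-out, the expectation for compound 4 is a small step at most, a number 5 percentage points higher from compound 2 to compound 4 (within the scatter), in this assay. Compound 4 is estimated at 5%, with a range from 0% to 25%.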

Compound 4, a percentage reported as inhibition, at one concentration (the size of the read-out at that concentration, not a potency): 0%
The estimate for compound 4 lay 5 percentage points above the measured number, and the stated range covers the measured number.
By their numbers in this assay, from the lowest: compounds 1, 2 and 4 (each within the scatter of the next); then compound 3.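

In this assay, the aromatic carbon carrying allyloxy now has a measured step: benzoyl in its place, which brings in a six-membered aromatic ring of carbon only, gives no change at the digits printed from compound 2 to compound 4 (within the scatter). This change on the ring thus stays within the scatter, unlike the exchange of the whole aryl group on the amide-type nitrogen, a number 25 percentage points higher from compound 2 to compound 3 (beyond the scatter). No measured evidence bears on this result.

As far as these compounds go, whether an amine or a carboxylic acid on this aromatic carbon would shift the number remains open. With compound 2 at 0%, any lowering from this position cannot be read.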